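Ring-homologue epimer pair: compound 3 to compound 4

The source may hold more compounds than are shown below. What is called first, only, known or untested is meant among the compounds shown, and "the series" means these compounds.

Measured so far in a functional assay on CHO-K1 cells for antagonist activity at Orexin/Hypocretin receptor type 1 (Homo sapiens), read by fluorescence and calcium flux, with a stated time of 30 min; a lower number here means a stronger inhibitor, a higher number a weaker inhibitor:
compound 1 `Cc1ccc(-n2nccn2)c(C(=O)N2CCC[C@@H]2Cn2ccc(-c3ccc(F)cn3)n2)c1`, 363 nM
compound 2 `Cc1ccc(-n2nccn2)c(C(=O)N2CCC[C@H]2Cn2ccc(-c3ccc(F)cn3)n2)c1`, 3.3 nM
compound 3 `Cc1ccc(-n2nccn2)c(C(=O)N2CCCC[C@@H]2Cn2ccc(-c3ccc(F)cn3)n2)c1`, 20.8 nM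

Compound 3 stands second highest of the three numbers; compound 2 sits a good way below it and compound 1 well above it, both gaps beyond the scatter. Compound 4 `Cc1ccc(-n2nccn2)c(C(=O)N2CCCC[C@H]2Cn2ccc(-c3ccc(F)cn3)n2)c1` is the other epimer of compound 3: the two compounds have the same atoms and bonds and differ only in configuration as drawn: 1 of 1 stereo elements differ; a stereocentre at a saturated ring carbon is drawn R in compound 3 and S in compound 4.

Within the data shown here, the one measured step that bears on this is a 110-fold lower number from compound 1 to compound 2 (2.04 log units; beyond the scatter), where the same kind of change, in the smaller saturated ring, gave a large drop in the number; that step rests on (the fact that compounds 1 and 2 differ only in the configuration as drawn). If the larger ring behaves alike, compound 4 should carry the configuration of compound 2 and come out stronger than compound 3, though compound 3 already stands far lower than compound 1, so the drop may be smaller. In this assay compound 4 is expected at 5 nM, within 1 nM to 30 nM, an estimated step of a 4.2-fold lower number from compound 3 to compound 4 (0.62 log units; beyond the scatter).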

Compound 4, half-maximal inhibitory concentration in the Orexin/Hypocretin receptor type 1 assay: 2.27 nM
Estimate against measurement, compound 4: 2.2-fold (0.34 log units) above; the measured number falls inside the stated range.
By their numbers in the Orexin/Hypocretin receptor type 1 assay, from the lowest: compounds 4 and 2 (each within the scatter of the next); then compound 3; then compound 1.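

In the Orexin/Hypocretin receptor type 1 assay the epimer preference seen in the smaller saturated ring recurs in the larger one, as a 9.2-fold lower number from compound 3 to compound 4 (0.96 log units; beyond the scatter) shows. In the Orexin/Hypocretin receptor type 1 assay compound 3 gives 20.8 nM and compound 4 gives 2.27 nM, while compound 1 gives 363 nM and compound 2 gives 3.3 nM, so in both pairs the configuration drawn S carries the lower number, although a 110-fold lower number from compound 1 to compound 2 (2.04 log units; beyond the scatter) is the larger step. Compound 4 and compound 2 lie within the scatter of each other in the Orexin/Hypocretin receptor type 1 assay, so the change of ring size leaves no readable difference between these two S epimers. In a physicochemical assay for lipophilicity, read by HPLC, at pH 7.4 (a higher number here means a more lipophilic compound, a lower number a more polar compound), compound 3 gives 2.95 and compound 4 gives 2.96. In the physicochemical assay the same change gives a number 0.01 log units higher from compound 3 to compound 4 (within the scatter) and therefore does not separate the pair, leaving the gap in the Orexin/Hypocretin receptor type 1 assay tied to a change of configuration alone: the fact that compounds 3 and 4 differ only in the configuration as drawn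

On these data alone, whether this preference survives a substituent on the saturated ring, such as a hydroxyl or a methyl group, remains open. Also open, as far as these compounds go, is whether it would hold with an amine in place of the fluorine on the shared core.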